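A few compounds are considered here, and "the series" means these few. Any claim that something is new, unique, unknown or untested is made for them only; others in the source may bear on it.

Going by the values given here, in a functional assay on HL-60 cells (Homo sapiens) for cytotoxicity, read by luminescence and CellTiter-Glo, with a stated time of 3 days (on this read-out higher numbers stand for weaker inhibition and lower numbers for stronger inhibition), compound 1 (`N#Cc1ccc(NC(=O)c2cc(-c3ccccc3)ccc2O)cc1`) gives 1350 nM and compound 2 (`N#Cc1ccc(NC(=O)c2cc(F)ccc2O)cc1`) gives 1420 nM, so compound 2 stands level with the only other measured compound. Compound 3 (`N#Cc1ccc(NC(=O)c2cc(-c3cccnc3)ccc2O)cc1`) has pyridin-3-yl in place of fluoro on an aromatic carbon. Among the compounds with values here, one measured step bears on this change: a 1.1-fold higher number from compound 1 to compound 2 (0.02 log units; within the scatter), with fluoro in place of phenyl on an aromatic carbon. That step lies within the scatter, so no step beyond the scatter, in either direction, is expected in this assay. The estimated value for compound 3 is 1500 nM, with a range of 700 nM to 3200 nM. This is the expected 1.1-fold higher number from compound 2 to compound 3 (0.02 log units; within the scatter).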

Compound 3, half-maximal inhibitory concentration: 7960 nM
For compound 3 the middle estimate is 5.3-fold (0.72 log units) below the measured one; the measured number lies above the stated range.
By their numbers in this assay, from the lowest: compounds 1 and 2 (each within the scatter of the next); then compound 3.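

In this assay, pyridin-3-yl on the aromatic carbon para to a hydroxy group brings a 5.6-fold higher number from compound 2 to compound 3 (0.75 log units; beyond the scatter), and in place of phenyl it brings a 5.9-fold higher number from compound 1 to compound 3 (0.77 log units; beyond the scatter). This shows that the position is not indifferent to its substituent, although fluoro and phenyl gave no difference beyond the scatter, and that the ring nitrogen setting pyridin-3-yl apart from phenyl goes with weaker inhibition here. Nothing available explains this change. As far as these compounds go, it remains open whether pyridin-4-yl, pyridin-2-yl or an amine on this carbon would match compound 3 or compound 1.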